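Catechol to guaiacol on the hydrazone aryl ring

A few compounds are considered here, and "the series" means these few. Any claim that something is new, unique, unknown or untested is made for them only; others in the source may bear on it.

Measured compounds:
compound 1 `COc1ccc(/C=N/NC(=O)Nc2ccc(Oc3ccnc(-c4nncn4CCN(C)C)c3)c(F)c2)c(OC)c1OC`: 7650 nM
compound 2 `CN(C)CCn1cnnc1-c1cc(Oc2ccc(NC(=O)N/N=C/c3ccc(O)c(O)c3)cc2F)ccn1`: > 100000 nM

Both numbers come from a functional assay on U-87MG ATCC cells (Homo sapiens) for cytotoxicity, read by MTT assay, with a stated time of 72 h; a lower number here means a stronger inhibitor, a higher number a weaker inhibitor. Compound 1 gives 7650 nM there. Compound 2 reaches only a limit of the assay, > 100000 nM, so no number is known for it. The step of an at least 13-fold higher number from compound 1 to compound 2 (1.11 log units; beyond the scatter) therefore sits at the limit of > 100000 nM in this assay, at which 1 of the 2 values shown sits, and its true size is open beyond that floor. Compound 2 stands at the weak end of the pair.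

Compound 3 `COc1cc(/C=N/NC(=O)Nc2ccc(Oc3ccnc(-c4nncn4CCN(C)C)c3)c(F)c2)ccc1O` differs from compound 2 by methyl in place of hydrogen on an oxygen on an aromatic ring. Within the data shown here, the only measured step bearing on this change is an at least 13-fold higher number from compound 1 to compound 2 (1.11 log units; beyond the scatter), which swapped a 2,3,4-trimethoxyphenyl for a 3,4-dihydroxyphenyl; compound 3 puts one methyl back on a ring oxygen and so lies partway toward compound 1. A step toward a lower number is expected in this assay, of size an at least 2.5-fold lower number from compound 2 to compound 3 (0.39 log units; beyond the scatter), though a further limit cannot be excluded. Compound 3 is estimated at 40000 nM, within 8000 nM to 200000 nM.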

Compound 3, half-maximal inhibitory concentration: > 100000 nM
Compound 3: only a limit was reported; the forecaster's own chance of this, stated with the estimate: 45%; middle value at least 2.5-fold (0.39 log units) from the limit.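

In this assay compound 3 also returns only a limit, > 100000 nM, so methyl in place of hydrogen on one ring oxygen does not bring the 3,4-dihydroxyphenyl series back to a readable value. The step between compound 2 and compound 3 cannot be read, and the two compounds sit together at one end of the range: the limit of > 100000 nM in this assay, at which 2 of the 3 values shown sit. Measured against the 2,3,4-trimethoxyphenyl compound, the change reads as an at least 13-fold higher number from compound 1 to compound 3 (1.11 log units; beyond the scatter), so a 4-hydroxy-3-methoxyphenyl on the hydrazone does not recover the value of compound 1, 7650 nM.

The compounds shown leave open whether the remaining hydroxy or the number of methoxy groups separates compound 3 from compound 1. A 3,4-dimethoxyphenyl, with no hydroxy left on the ring, would bear directly on that question.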